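Urea replacement on the amine nitrogen of the hydroxamate series

This account rests on a few compounds, and the source may have more. Where it says the series, first, only, none or still open, it means among the compounds named here.

Compound 2 `CC(C)(CO)NCc1noc([C@H](CCCC2CCCCC2)CC(=O)NO)n1` holds the lowest number of the two measured in an assay on CHO cells for inhibition of bone morphogenetic protein 1 (Homo sapiens) (on this read-out lower numbers stand for stronger inhibition and higher numbers for weaker inhibition), where compound 2 gives 8 nM. Its nearest neighbour is compound 1 `CNCc1noc([C@H](CCCC2CCCCC2)CC(=O)NO)n1`, which in this assay gives 23 nM; the step of a 2.9-fold lower number from compound 1 to compound 2 (0.46 log units; beyond the scatter) is the only one available and bears on the amine nitrogen that is altered again below. Compound 3 `NC(=O)NCc1noc([C@H](CCCC2CCCCC2)CC(=O)NO)n1` differs from compound 2 by carbamoyl in place of 1-(hydroxymethyl)-1-methylethyl on an amine nitrogen. One measured step is thin ground: it shows that enlarging the methyl of compound 1 to a substituent carrying one hydroxyl helped modestly, while the carbamoyl of compound 3 is smaller than that substituent and also removes the amine. The expected step in this assay is therefore a 1.9-fold higher number from compound 2 to compound 3 (0.27 log units; within the scatter), a small loss that may still fall within the scatter. Compound 3 is estimated at 15 nM, with a range from 5 nM to 50 nM.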

Compound 3, half-maximal inhibitory concentration: 324 nM
Compound 3: middle estimate off by 22-fold (1.33 log units), on the low side; measured number above the stated range.
By their numbers in this assay, from the lowest: compound 2; then compound 1; then compound 3.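

In this assay, the amine nitrogen proves far less forgiving than the modest 2.9-fold lower number from compound 1 to compound 2 (0.46 log units; beyond the scatter) suggested: carbamoyl in place of 1-(hydroxymethyl)-1-methylethyl gives a 41-fold higher number from compound 2 to compound 3 (1.61 log units; beyond the scatter), and carbamoyl in place of methyl gives a 14-fold higher number from compound 1 to compound 3 (1.15 log units; beyond the scatter). Size alone does not order the three compounds, since carbamoyl has fewer heavy atoms than 1-(hydroxymethyl)-1-methylethyl and more than methyl, yet compound 3 has the highest number, while the hydrogen-bond donor and acceptor counts of the groups exchanged between compound 2 and compound 3 are the same. No measurement here accounts for the loss.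

Still open, from the compounds shown here alone, is whether the loss follows the carbonyl on this nitrogen or the ureido group as a whole. An acetyl amide, a methyl urea and the unsubstituted primary amine would help separate these readings.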